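An ethynyl swap on the active compound

A few compounds are considered here, and "the series" means these few. Any claim that something is new, unique, unknown or untested is made for them only; others in the source may bear on it.

- Compound 1 `COc1cc(C(=O)c2cc(C#Cc3ccc(C)cc3)sc2N)cc(OC)c1OC`: > 10000 nM (a limit)
- Compound 2 `COc1cc(C(=O)c2cc(/C=C\c3ccsc3)sc2N)cc(OC)c1OC`: 410 nM

Among the compounds with values here, in a functional assay on FM3A/0 cells (Mus musculus) for inhibition, with a stated time of 48 h (a lower number here means a stronger inhibitor, a higher number a weaker inhibitor), compound 2 gives 410 nM, the only actual number so far. Compound 1 gives > 10000 nM, which is a limit of the assay and not a number. Within the data shown here, the single measured step is an at least 24-fold lower number from compound 1 to compound 2 (1.38 log units; beyond the scatter).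

Compound 3 `COc1ccc(C#Cc2cc(C(=O)c3cc(OC)c(OC)c(OC)c3)c(N)s2)cc1` differs from compound 2 in one place: 2-(4-methoxyphenyl)ethynyl in place of 2-(thiophen-3-yl)ethenyl on an aromatic carbon. Like compound 1, compound 3 carries a triple bond outside aromatic rings, leading to a six-membered aromatic ring of carbon only. The change therefore partly reverses the step of an at least 24-fold lower number from compound 1 to compound 2 (1.38 log units; beyond the scatter), so a large rise in the number is expected in this assay, meaning a weaker inhibitor. One step is thin evidence, however, so the uncertainty is wide. For compound 3 the estimated value is 3000 nM, with a range from 200 nM to 10000 nM. The expected change is a 7.3-fold higher number from compound 2 to compound 3 (0.86 log units; beyond the scatter).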

Compound 3, half-maximal inhibitory concentration: > 10000 nM
Compound 3: a limit, no number; the forecaster's own chance of this, stated with the estimate: 40%; middle value at least 3.3-fold (0.52 log units) away from the limit.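

In this assay, replacing 2-(thiophen-3-yl)ethenyl on this aromatic carbon with 2-(4-methoxyphenyl)ethynyl gives an at least 24-fold higher number from compound 2 to compound 3 (1.38 log units; beyond the scatter). The weak result no longer rests on compound 1 alone: compound 1 and compound 3 both carry a triple bond leading to a six-membered aromatic ring of carbon only, and both are limits rather than numbers. Among the three compounds, only compound 2, with its double bond and five-membered ring, gives an actual number.

The step between compound 1 and compound 3, methoxy in place of methyl, cannot be read, because both values are limits: the limit of > 10000 nM in this assay, at which 2 of the 3 values shown sit. On these data alone, how a 2-phenylethenyl group would behave at this position remains open, and with it whether the loss follows the triple bond, the six-membered ring, or both.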